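A few compounds are considered here, and "the series" means these few. Any claim that something is new, unique, unknown or untested is made for them only; others in the source may bear on it.

Series notes. Compound 1 `N#Cc1c(-c2ccco2)nc2c(c(-c3ccccc3)nn2-c2ccccc2)c1-c1ccc(O)cc1` carries a furan-2-yl group and a 4-hydroxyphenyl group on the shared core. In a functional assay on CCRF-CEM cells (Homo sapiens) for antiproliferative activity, read by resazurin assay, with a stated time of 72 h (on this read-out lower numbers stand for stronger inhibition and higher numbers for weaker inhibition), compound 1 gives 23900 nM, the lowest of the two numbers recorded so far, although its neighbour compound 2 `COc1cc(-c2c(C#N)c(-c3ccco3)nc3c2c(-c2ccccc2)nn3-c2ccccc2)ccc1O` lies within the scatter of it: in this assay compound 2 gives 36500 nM. Among the measured compounds shown here, the only measured step is a 1.5-fold higher number from compound 1 to compound 2 (0.18 log units; within the scatter), a change at the 4-hydroxyphenyl group, and it produced nothing beyond the scatter.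

Compound 3 `N#Cc1c(-c2ccc(Cl)cc2)nc2c(c(-c3ccccc3)nn2-c2ccccc2)c1-c1ccc(O)cc1` differs from compound 1 at a different place: 4-chlorophenyl in place of furan-2-yl on an aromatic carbon. For the measured compounds named here, no measured pair alters the group at this place, so the step from compound 1 to compound 3 has no direct precedent; the one recorded step concerns another site and gives no guide to direction. On this basis no step beyond the scatter is expected in this assay, with wide uncertainty. For compound 3 the estimated value is 22000 nM, with an expected range from 6000 nM to 80000 nM, which corresponds to an expected step of a 1.1-fold lower number from compound 1 to compound 3 (0.04 log units; within the scatter).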

Compound 3, half-maximal inhibitory concentration: 43100 nM
Compound 3: the middle estimate sits 2.0-fold (0.29 log units) below what was measured; low and high end bracket the measured number.
By their numbers in this assay, from the lowest: compounds 1, 2 and 3 (each within the scatter of the next).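

In this assay the carbon next to the ring nitrogen and ortho to a cyano group now has its first measured step, which is a 1.8-fold higher number from compound 1 to compound 3 (0.26 log units; within the scatter) and so joins the change at the 4-hydroxyphenyl group as a single change that stays within the scatter. At this place, furan-2-yl, a five-membered aromatic ring with 1 hetero atom, and 4-chlorophenyl, a six-membered aromatic ring of carbon only, are not told apart by this read-out, so the furan-2-yl group is not needed to keep the number in this range. No measured information bears on the reason for this result.

Only these two aromatic groups have been compared at this carbon, so the step says nothing about other kinds of group. As far as these compounds go, whether an amine or a carboxylic acid in place of furan-2-yl would give a step beyond the scatter remains open.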